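Adding One Chain Carbon to a Hydroxycarbamoyl Side Chain

A few compounds are considered here, and "the series" means these few. Any claim that something is new, unique, unknown or untested is made for them only; others in the source may bear on it.

Compound 1 `O=S(=O)(c1ccccc1)c1c(OCCCCCCO)no[n+]1[O-]` and compound 2 `O=C(CCCOc1no[n+]([O-])c1S(=O)(=O)c1ccccc1)NO` share the same core. In a functional assay on HeLa cells (Homo sapiens) for inhibition, read by MTT assay, with a stated time of 48 h (on this read-out higher numbers stand for weaker inhibition and lower numbers for stronger inhibition), compound 1 has the entry "not determined" (no result reported) and so offers nothing to compare. In this assay, for the measured compounds named here, compound 2 gives 4790 nM as the only number available, which makes it a single reference point and not a place in a ranking.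

Compound 3 `O=C(CCCCOc1no[n+]([O-])c1S(=O)(=O)c1ccccc1)NO` differs from compound 2 in one place: (hydroxycarbamoyl)methyl in place of hydroxycarbamoyl on a saturated chain carbon, three bonds along the chain from an oxygen on an aromatic ring with (hydroxycarbamoyl)methyl in place of hydroxycarbamoyl on a saturated chain carbon, three bonds along the chain from an oxygen on an aromatic ring. Cut one bond further out, this reads 3-(hydroxycarbamoyl)propyl to 4-(hydroxycarbamoyl)butyl, so the chain simply grows while its hydroxycarbamoyl end stays.

Going by the values given here, no measured pair shows what such a lengthening does here, so the expectation rests on compound 2 at 4790 nM and on how small the change is. The estimated change a 1.4-fold lower number from compound 2 to compound 3 (0.14 log units; within the scatter) is expected to stay within the usual scatter, leaning slightly toward stronger inhibition. In this assay compound 3 is estimated at 3500 nM with an expected range from 1200 nM to 10000 nM around that figure.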

Compound 3, half-maximal inhibitory concentration: 3650 nM
Estimate against measurement, compound 3: 1.0-fold (0.02 log units) below, and the stated range covers the measured number.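

Lengthening the chain from 3-(hydroxycarbamoyl)propyl to 4-(hydroxycarbamoyl)butyl gives the first measured step at this position, and in this assay it is a 1.3-fold lower number from compound 2 to compound 3 (0.12 log units; within the scatter) for this change. With the hydroxycarbamoyl end kept in place, the two chain lengths cannot be told apart on this read-out, so this position tolerates the change without a clear gain or loss, and compound 2 is no longer a lone reference point. Nothing in the available data explains why the read-out holds steady across this change.

Two neighbouring chain lengths are only a short stretch of the series, so they cannot show whether a longer chain such as 5-(hydroxycarbamoyl)pentyl, or the shorter (hydroxycarbamoyl)methyl, would keep the number in the same range. They also leave open how much the hydroxycarbamoyl end itself contributes, a question that a carboxylic acid or an amine at the end of the same chain would address directly.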